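Working notes: swapping the dimethoxyphenyl isomer

The source may report more compounds than this note shows. Statements on the series, on what has been measured and on what is new or still open speak of the compounds shown alone.

- compound 1 `COc1ccc(/C=C/C(=O)/C=C/c2cc3ccccc3nc2Oc2ccc(Br)cc2)cc1OC` | > 10000 nM (a limit)
- compound 2 `COc1ccc(/C=C/C(=O)/C=C/c2cc3ccccc3nc2Oc2cccc(Cl)c2)c(OC)c1` | > 10000 nM (a limit)

In a functional assay on HeLa cells (Homo sapiens) for cytotoxicity, read by MTT assay, with a stated time of 48 h (a lower number here means a stronger inhibitor, a higher number a weaker inhibitor), compound 2 gives > 10000 nM, which is a limit and not a number. Within the data shown here, the series so far shows only (the limit of > 10000 nM in this assay, at which 2 of the 2 values shown sit), and no measured step.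

Compound 3 `COc1ccc(/C=C/C(=O)/C=C/c2cc3ccccc3nc2Oc2cccc(Cl)c2)cc1OC` carries 3,4-dimethoxyphenyl in place of 2,4-dimethoxyphenyl on a double-bonded chain carbon bound to a double-bonded chain carbon.

Compound 1, which also carries 3,4-dimethoxyphenyl, gives > 10000 nM, again a limit. The expected step that the limit leaves unreadable from compound 2 to compound 3 is estimated to stay within the scatter, in no particular direction. For compound 3 the expected value in this assay is 15000 nM, with an estimated range of 7000 nM to 30000 nM.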

Compound 3, half-maximal inhibitory concentration: > 10000 nM
Compound 3: no number, only a limit (the forecaster's own chance of this, stated with the estimate: 75%); the middle value lies beyond the limit too.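

Among these compounds, compound 1, compound 2 and compound 3 stand only as limits in this assay, and no step among them can be read. The compounds shown leave open whether either 3,4-dimethoxyphenyl in place of 2,4-dimethoxyphenyl or 3-chlorophenyl in place of 4-bromophenyl changes cytotoxicity at all: the limit of > 10000 nM in this assay, at which 3 of the 3 values shown sit.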